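Neopentyl in Place of Isopropyl: An Expected Step

The compounds below may be only part of what the source reports. "The series", "measured", "known", "first", "only" and "open" are said of these compounds alone.

Compound 1, `C/C(=C/c1ccc(Cc2cccnc2)n1C(C)C)C(=O)O`: 2100 nM
Compound 2, `Cn1c(/C=C/C(=O)O)ccc1Cn1ccnc1`: 3800 nM

Of the compounds shown here, two have been measured in a functional assay on microsomes from aorta for inhibition of Thromboxane-A synthase (Homo sapiens), in the presence of a further agent that is not named here; a higher number here means a weaker inhibitor, a lower number a stronger inhibitor. Compound 1 gives 2100 nM in this assay. Compound 2, which carries a different core and a different ring on its side chain, gives 3800 nM. The gap between these two numbers lies within the usual scatter of repeated measurements, so nothing can be said about which of the two is the better inhibitor; compound 1 simply stands at one end of a pair whose values cannot be told apart.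

Compound 3, `C/C(=C/c1ccc(Cc2cccnc2)n1CC(C)(C)C)C(=O)O`, has not yet been measured. It differs from compound 1 by a single exchange: neopentyl in place of isopropyl on an aromatic nitrogen. Going by the values given here, no measured pair in this set shows what such an exchange does in this assay, so any expectation rests on compound 1 alone and on the general observation that small changes of this kind often move the number only modestly.

The step from compound 1 to compound 3 is estimated at a 1.2-fold higher number from compound 1 to compound 3 (0.08 log units; within the scatter), that is, no clear change beyond the scatter in either direction. Compound 3 is therefore expected to give about 2500 nM in this assay, with a plausible range from 900 nM to 7000 nM.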

Compound 3, half-maximal inhibitory concentration: 78000 nM
The estimate for compound 3 lay 31-fold (1.49 log units) below the measured number; the measured number lies above the stated range.
By their numbers in this assay, from the lowest: compounds 1 and 2 (each within the scatter of the next); then compound 3.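

In this assay, the group on the aromatic nitrogen of the shared core proves to be anything but a neutral spot: neopentyl in place of isopropyl gives a 37-fold higher number from compound 1 to compound 3 (1.57 log units; beyond the scatter), a clear weakening of inhibition. Compounds 1 and 2 differ in more than one place and could not show this; here, a change of only carbon atoms, with no ring, hydrogen-bond donor, hydrogen-bond acceptor or net charge entering or leaving, is enough to produce a large step. Nothing available here explains why this exchange has so large an effect.

Going by these compounds, with only isopropyl and neopentyl compared on this core, it remains open whether the number rises steadily as the carbon group grows or whether neopentyl alone is poorly accepted. An ethyl group, a straight butyl chain or a cyclopropyl ring on the same nitrogen would help to separate these possibilities, and a short chain ending in an amine or a carboxylic acid would show whether a group carrying a charge is accepted there.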